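Notes on a cyclobutyl replacement for methyl

The compounds below may be only part of what the source reports. "The series", "measured", "known", "first", "only" and "open" are said of these compounds alone.

Three compounds have values in a physicochemical assay for solubility, read by HPLC, in phosphate buffer, measured as kinetic solubility, at pH 7.4; on this read-out lower numbers stand for lower solubility and higher numbers for higher solubility. Compound 1 (`CCC(=O)c1cc(-c2ccc(Cl)cc2)[nH]c1C`) gives 900 nM in this assay. Compound 2 (`CCOC(=O)c1cc(-c2ccc(Cl)cc2)n(-c2ccc(S(N)(=O)=O)cc2)c1N`) gives 4400 nM in the same read-out. Compound 3 (`CCC(=O)c1cc(-c2ccc(S(N)(=O)=O)cc2)n(-c2ccc(Cl)cc2)n1`) gives 41900 nM as the highest of the three numbers. Compound 2 is its nearest neighbour and compound 1 its furthest, and both gaps lie beyond the scatter.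

Compound 4 (`NS(=O)(=O)c1ccc(-c2cc(C(=O)CC3CCC3)nn2-c2ccc(Cl)cc2)cc1`) has not been measured. It carries cyclobutyl in place of methyl on a saturated chain carbon bound to a carbonyl carbon. Among the measured compounds shown here, no two measured compounds differ in one place only, so the series gives no direct measure of this change and the expectation remains a judgement. Compound 3 starts from the top of the measured range, and a lower number beyond the scatter is expected. The expected size is a 3.0-fold lower number from compound 3 to compound 4 (0.48 log units; beyond the scatter) on present evidence. For compound 4 the estimated value is 14000 nM with an expected range from 4000 nM to 35000 nM in this assay.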

Compound 4, solubility: 4300 nM
Compound 4: the middle estimate sits 3.3-fold (0.51 log units) above what was measured; measured number inside the range.
By their numbers in this assay, from the lowest: compound 1; then compounds 4 and 2 (each within the scatter of the next); then compound 3.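

In this assay, among the compounds shown here, cyclobutyl in place of methyl on a saturated chain carbon bound to a carbonyl carbon gives a 9.7-fold lower number from compound 3 to compound 4 (0.99 log units; beyond the scatter) and provides the first direct reading of a single change. This place therefore responds to the change beyond the scatter, although only carbon enters and no hydrogen-bond donors or acceptors enter or leave. Nothing available explains the size of this step.

With one step at one place, the ring cannot be separated from the longer carbon skeleton, and a straight pentyl chain on the same carbon would be needed to tell them apart. Also open, from the compounds shown here alone, is whether an amine or a carboxylic acid on that carbon would keep the number nearer that of compound 3, and whether cyclobutyl behaves alike on other cores.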